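This account rests on a few compounds, and the source may have more. Where it says the series, first, only, none or still open, it means among the compounds named here.

Compound 1 `N#Cc1ccc(Nc2ncnc3ccc(-c4ccc(C(=O)N5CCNCC5)cc4)nc23)cc1` and compound 2 `CCCNC(=O)c1cccc(C#Cc2ccccc2Nc2ncnc3ccc(Cl)nc23)c1` share a core but carry very different groups around it. In an assay on isolated protein for inhibition of MAP kinase-interacting serine/threonine-protein kinase 1 (Homo sapiens), read by HTRF, in the presence of a further agent that is not named here (a higher number here means a weaker inhibitor, a lower number a stronger inhibitor), compound 1 gives 0.15 nM. Compound 2 gives only a limit of the assay, > 10000 nM. Compound 2 therefore stands at the limit of > 10000 nM in this assay, at which 1 of the 2 values shown sits, and no exact number exists for it. Compound 3 `CN(C)C(=O)c1cccc(C#Cc2ccccc2Nc2ncnc3ccc(Cl)nc23)c1` is derived from compound 2 by one change: dimethylamino in place of propylamino on a carbonyl carbon. Within the data shown here, no measured pair shows a step of this kind, so the data give no direct guide to its size or direction. The step that the limit leaves unreadable from compound 2 to compound 3 is expected to lie within the usual scatter, with compound 3 most likely again reaching only a limit rather than a number. On that basis compound 3 is estimated at 20000 nM in this assay, with a range from 5000 nM to 100000 nM.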

Compound 3, half-maximal inhibitory concentration: > 10000 nM
Compound 3 ended at the assay's limit; the forecaster's own chance of this, stated with the estimate: 85%; the middle value lies beyond the limit too.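

Among these compounds, compound 2 and compound 3 both end at a limit of the assay rather than at a number, so no step between them can be read: the limit of > 10000 nM in this assay, at which 2 of the 3 values shown sit. The compounds shown leave open whether dimethylamino in place of propylamino on the carbonyl carbon changes inhibition at all.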